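This account rests on a few compounds, and the source may have more. Where it says the series, first, only, none or still open, it means among the compounds named here.

Among the measured compounds shown here, compound 2 `N#C/C(=C\c1ccco1)C(=O)NCc1ccc(Cl)c(Cl)c1` gives 20000 nM in a functional assay on HT-29 cells (Homo sapiens) for inhibition, read by MTT assay, with a stated time of 72 h (a lower number here means a stronger inhibitor of growth, a higher number a weaker inhibitor of growth), the second highest of the three numbers measured so far. Compound 1 `N#C/C(=C\c1ccc[nH]1)C(=O)NCc1ccc(Cl)c(Cl)c1` gives 85000 nM, and compound 3 `COc1ccc(CNC(=O)/C(C#N)=C/c2ccc(Cl)cc2)cc1`, built on a different core, gives 7000 nM. For the measured compounds named here, the only single-place step among them, a 4.3-fold lower number from compound 1 to compound 2 (0.63 log units; beyond the scatter), replaces one ring on the chain carbon with another. Compound 4 `N#C/C(=C\c1ccccc1)C(=O)NCc1ccc(Cl)c(Cl)c1` differs from compound 2 by phenyl in place of furan-2-yl on a double-bonded chain carbon bound to a double-bonded chain carbon. Going by the values given here, no measured step covers this change directly; the step from compound 1 to compound 2 shows only that the ring on that chain carbon can move the number modestly. A modest shift in this assay is therefore expected, with no firm reason to favour either direction. The estimate for compound 4 is 12000 nM, between 4000 nM and 40000 nM, which corresponds to a step of a 1.7-fold lower number from compound 2 to compound 4 (0.22 log units; within the scatter).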

Compound 4, concentration for 50% growth inhibition: 70000 nM
Beside the measured number, compound 4's estimate is 5.8-fold (0.77 log units) below it; the measured number lies above the stated range.
By their numbers in this assay, from the lowest: compound 3; then compound 2; then compounds 4 and 1 (each within the scatter of the next).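

Replacing furan-2-yl with phenyl on the double-bonded chain carbon gives a 3.5-fold higher number from compound 2 to compound 4 (0.54 log units; beyond the scatter) in this assay, so the ring at this place moves the number upward as well as downward. Phenyl and 1H-pyrrol-2-yl, however, do not separate, with a 1.2-fold lower number from compound 1 to compound 4 (0.08 log units; within the scatter), which leaves furan-2-yl as the only one of these three rings with a lower number. Nothing available accounts for this difference.

The compounds shown leave open how a pyridine ring, or an open chain ending in an amine, would read at this place on the shared core.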